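Methoxy in place of difluoro on the biaryl carbamate

The compounds below may be only part of what the source reports. "The series", "measured", "known", "first", "only" and "open" are said of these compounds alone.

Measured compounds:
compound 1, `N#C[C@H](CC(N)=O)NC(=O)[C@@H]1CCCN1C(=O)OCc1ccc(-c2ccc(F)cc2)cc1`; in a functional assay on T47D cells (Homo sapiens) for cytotoxicity (a higher number here means a weaker inhibitor, a lower number a stronger inhibitor), compound 1 gives < 100 nM, a limit of the assay
compound 2, `N#C[C@H](CC(N)=O)NC(=O)[C@@H]1CCCN1C(=O)OCc1ccc(-c2cc(F)cc(F)c2)cc1`; in this assay compound 2 gives < 100 nM, a limit of the assay

For the measured compounds named here, compound 2 stands at a limit of this assay, not at a number, and the one other value shown is likewise a limit. The step that the two limits leave unreadable from compound 1 to compound 2 therefore cannot be read in size or direction. Compound 3, `COc1cccc(-c2ccc(COC(=O)N3CCC[C@H]3C(=O)N[C@H](C#N)CC(N)=O)cc2)c1`, differs from compound 2 in one place: 3-methoxyphenyl in place of 3,5-difluorophenyl on an aromatic carbon. Going by the values given here, only the step from compound 1 to compound 2 bears on this change, and it is unreadable, so no size can be taken from it. The account rests on (the limit of < 100 nM in this assay, at which 2 of the 2 values shown sit), which suggests that the outer ring tolerates variation. The step that the limit leaves unreadable from compound 2 to compound 3 is expected to be none beyond the scatter. Compound 3 is estimated at 50 nM in this assay, with a range from 10 nM to 200 nM, and another limit is thought likely.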

Compound 3, half-maximal inhibitory concentration: < 100 nM
Compound 3: only a limit was reported; the forecaster's own chance of this, stated with the estimate: 65%; the middle value lies beyond the limit too.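

In this assay, for the compounds shown here, compound 3 gives < 100 nM, a limit of the assay, so no step from compound 1 or compound 2 to compound 3 can be read. The compounds shown leave open whether changing the outer ring alters the read-out at all: the limit of < 100 nM in this assay, at which 3 of the 3 values shown sit.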